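The compounds below may be only part of what the source reports. "The series", "measured", "known", "first", "only" and "open" are said of these compounds alone.

Measured so far:
compound 1, `COc1cc2c(cc1OC)C(CC(=O)O)CC2`, in a functional assay on the whole organism (strain Wistar) for inhibition, with Rattus norvegicus as the target, read by paw edema, with a stated time of 4 h, at a dose of 100 mg/kg (a higher number here means more inhibition at the dose given (going by the name of the read-out), a lower number less inhibition), gives 23.9%;
compound 2, `COc1cc2c(cc1OC)C(CC(=O)Nc1ccc(Cl)cc1)CC2`, in this assay gives 60.9%.

Within the data shown here, of these two numbers, compound 2 stands highest, and the only step measured, a number 37 percentage points higher from compound 1 to compound 2 (beyond the scatter), carries from the acid to the anilide. Compound 3, `COc1cc2c(cc1OC)C(CC(=O)Nc1cccc(C)c1)CC2`, keeps the shared core and the amide and changes only the ring on the amide nitrogen: 3-methylphenyl in place of 4-chlorophenyl on an amide-type nitrogen. Among the measured compounds shown here, no measured step swaps one aryl group for another on that nitrogen, so the one step available gives little guidance beyond showing that an anilide of this core can reach the range of compound 2. On that basis the expected change in this assay is small and could fall in either direction within the scatter; the estimated step is a number 8.9 percentage points lower from compound 2 to compound 3 (within the scatter). Compound 3 is therefore expected to give about 52%, within a range of 30% to 72%.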

Compound 3, a percentage reported as inhibition, in the whole organism at one dose (the size of the read-out at that dose, not a potency): 40.6%
Estimate against measurement, compound 3: 11.4 percentage points above; measured number inside the range.
By their numbers in this assay, from the lowest: compound 1; then compound 3; then compound 2.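

In this assay, the group on the amide nitrogen clearly matters: 3-methylphenyl in place of 4-chlorophenyl gives a number 20.3 percentage points lower from compound 2 to compound 3 (beyond the scatter) even though both groups have the same count of heavy atoms and neither has hydrogen-bond donors or acceptors. Still, (3-methylphenyl)amino in place of hydroxy on the carbonyl carbon gives a number 16.7 percentage points higher from compound 1 to compound 3 (beyond the scatter) and so shows that the gain over the acid is not limited to the 4-chlorophenyl anilide. Nothing measured here explains the difference between the two anilides.

This change alters both the ring substituent and its position, so the two effects cannot be separated. Either 4-methylphenyl or 3-chlorophenyl on the same nitrogen would change only one of them, while unsubstituted phenyl would show what the ring does without a substituent.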